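From methoxycarbonyl to 2-bromoethyl on the amide side chain

The source may hold more compounds than are shown below. What is called first, only, known or untested is meant among the compounds shown, and "the series" means these compounds.

In a functional assay on MCF7 cells (Homo sapiens) for inhibition, read by radiometric assay and XTT assay (on this read-out lower numbers stand for stronger inhibition and higher numbers for weaker inhibition), compound 1 `CCCCCC[C@@]1(C)SC(=O)C=C1OCC(=O)OCC` gives 39.6 ug/mL and compound 2 `C=CCOC1=CC(=O)S[C@]1(C)CCCCCC` gives 9 ug/mL on the same scale. Compound 3 `CCCCCC[C@@]1(C)SC(=O)C=C1OCC(=O)NCC(=O)OC` gives 40.5 ug/mL and so sits level with compound 1 at the high end of these numbers. Compound 4 `CCCCCC[C@@]1(C)SC(=O)C=C1OCC(=O)NCCCBr` carries 2-bromoethyl in place of methoxycarbonyl on a saturated chain carbon bound to an amide-type nitrogen. Going by the values given here, two measured steps bear on this. Vinyl in place of ethoxycarbonyl gave a 4.4-fold lower number from compound 1 to compound 2 (0.64 log units; beyond the scatter) while ((methoxycarbonyl)methyl)amino in place of ethoxy gave a 1.0-fold higher number from compound 1 to compound 3 (0.01 log units; within the scatter) and stayed within the scatter. Only the first removes an ester, as this change does, so a smaller step toward lower numbers is expected (a 1.6-fold lower number from compound 3 to compound 4 (0.21 log units; within the scatter)). For compound 4 the estimated value is 25 ug/mL with 10 ug/mL to 55 ug/mL as the expected range.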

Compound 4, half-maximal inhibitory concentration: 21 ug/mL
Compound 4: middle estimate off by 1.2-fold (0.08 log units), on the high side; measured number inside the range.
By their numbers in this assay, from the lowest: compound 2; then compounds 4, 1 and 3 (each within the scatter of the next).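

In this assay, replacing methoxycarbonyl with 2-bromoethyl at this place gives a 1.9-fold lower number from compound 3 to compound 4 (0.29 log units; within the scatter) and does not separate the two compounds, and (3-bromopropyl)amino in place of ethoxy gives a 1.9-fold lower number from compound 1 to compound 4 (0.28 log units; within the scatter) and likewise stays within the scatter. Compound 2, with vinyl on the oxygen-bound chain carbon, remains apart, with a 2.3-fold higher number from compound 2 to compound 4 (0.37 log units; beyond the scatter) as a modest step beyond the scatter. Nothing measured here gives a reason for these differences.

Still open, as far as these compounds go, is whether a free amine or a carboxylic acid at the end of this side chain would shift the number. A longer chain carrying the bromine is equally untested by the compounds shown.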